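Swapping fluoro for methyl on the aroyl ring

A few compounds are considered here, and "the series" means these few. Any claim that something is new, unique, unknown or untested is made for them only; others in the source may bear on it.

Measured in a functional assay on a cell-free system (Platelet, plasma, Homo sapiens) for inhibition; on this read-out higher numbers stand for weaker inhibition and lower numbers for stronger inhibition:
Compound 1 `COc1ccc(C(=O)N(CCN2CCC(OCC(=O)O)CC2)c2ccc(Cl)cc2)cc1`: 3100 nM
Compound 2 `O=C(O)COC1CCN(CCN(C(=O)c2cccc(F)c2)c2ccc(Cl)cc2)CC1`: 340 nM
Not yet measured: compound 3 `Cc1cccc(C(=O)N(CCN2CCC(OCC(=O)O)CC2)c2ccc(Cl)cc2)c1`

Of the two numbers in this assay, the lower belongs to compound 2 at 340 nM, and the gap to the other number lies beyond the scatter. Compound 3 differs from compound 2 in one place, with methyl in place of fluoro on an aromatic carbon, meta to a large group (methyl in place of fluoro on an aromatic carbon). Within the data shown here, only one measured step bears on this change. It is a 9.1-fold lower number from compound 1 to compound 2 (0.96 log units; beyond the scatter), a modest step in which 3-fluorophenyl replaced 4-methoxyphenyl on a carbonyl carbon. Among the measured compounds shown here, that step shows that the number responds to this part of the molecule, but it exchanged a differently substituted group, and no measured pair compares fluoro with methyl directly. Compound 3 is therefore expected to stay much nearer to compound 2 than to compound 1, perhaps slightly higher. The expected step is a 1.3-fold higher number from compound 2 to compound 3 (0.12 log units; within the scatter), which would not be expected to exceed the scatter. For compound 3 the estimated value is 450 nM, within an expected range of 150 nM to 1300 nM.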

Compound 3, half-maximal inhibitory concentration: 310 nM
Compound 3: middle estimate off by 1.5-fold (0.16 log units), on the high side; the measured number falls inside the stated range.
By their numbers in this assay, from the lowest: compounds 3 and 2 (each within the scatter of the next); then compound 1.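

In this assay, exchanging fluoro for methyl on this aromatic carbon gives a 1.1-fold lower number from compound 2 to compound 3 (0.04 log units; within the scatter), so at this position the read-out does not tell the two single-atom groups apart. The comparison with the 4-methoxyphenyl compound now rests on two steps, a 9.1-fold lower number from compound 1 to compound 2 (0.96 log units; beyond the scatter) and a 10-fold lower number from compound 1 to compound 3 (1.00 log units; beyond the scatter), which shows that the gap from compound 1 is not tied to fluoro: 3-fluorophenyl and 3-methylphenyl both stand beyond the scatter from it, and within the scatter of each other. Nothing measured here accounts for this result.

Both steps from compound 1 exchange the substituent and its place on the ring together, so the compounds shown cannot separate what belongs to the methoxy group from what belongs to where the substituent sits. They also leave open whether the same insensitivity would hold beyond fluoro and methyl, for instance for a chloro group, a nitrile, a hydroxyl or an unsubstituted phenyl on the same carbonyl.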